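The compounds below may be only part of what the source reports. "The series", "measured", "known", "first", "only" and "open" are said of these compounds alone.

Working notes on the series. The shared core of compound 1 `Nc1scc(CN2CCN(c3ccc(Cl)c(C(F)(F)F)c3)CC2)c1C(=O)c1ccc(Cl)cc1` holds a six-membered non-aromatic ring with 2 nitrogen, and the group on its amine nitrogen in a ring is the point of variation. In a functional assay on CHO cells with adenosine receptor A1 (Homo sapiens) as the target, read by cAMP accumulation and immunoassay, with a stated time of 6 min, tested at 0.01 uM (on this read-out higher numbers stand for a weaker effect at the one concentration tested and lower numbers for a stronger effect), compound 1 gives -2.5%. Compound 2 `Nc1scc(CN2CCN(C3CCCCCC3)CC2)c1C(=O)c1ccc(Cl)cc1` carries cycloheptyl there; in this assay compound 2 gives 2.9%. Among the measured compounds shown here, of the two numbers so far, compound 2 sits at the top, but its only neighbour is compound 1 and the single measured step, a number 5.4 percentage points higher from compound 1 to compound 2 (within the scatter), lies within the scatter, so the two are not distinguished on this read-out. Compound 3 `Nc1scc(CN2CCN(c3ccccc3F)CC2)c1C(=O)c1ccc(Cl)cc1` has not been measured. It differs from compound 2 by 2-fluorophenyl in place of cycloheptyl on an amine nitrogen in a ring. For the measured compounds named here, the one step that bears on this change swapped 4-chloro-3-(trifluoromethyl)phenyl for cycloheptyl and stayed within the scatter; the move to 2-fluorophenyl on the same amine nitrogen in a ring has no measured precedent pointing beyond it. Compound 3 is therefore expected to stay near the baseline, with an expected step of a number 2.9 percentage points lower from compound 2 to compound 3 (within the scatter). The estimate for compound 3 in this assay is 0%, ranging from -12% to 12%.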

Compound 3, a percentage reported as activity, at one concentration (the size of the read-out at that concentration, not a potency): 2.1%
Compound 3: the middle estimate sits 2.1 percentage points below what was measured; low and high end bracket the measured number.
By their numbers in this assay, from the lowest: compounds 1, 3 and 2 (each within the scatter of the next).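

In this assay, the group on the amine nitrogen in a ring has now been changed to an aromatic ring as well as a non-aromatic one, and the read-out does not separate them (a number 0.8 percentage points lower from compound 2 to compound 3 (within the scatter)). The aromatic 2-fluorophenyl and the non-aromatic cycloheptyl have the same heavy-atom count of 7, so this pair isolates a change of ring type at equal heavy-atom count, whereas the earlier step also changed the size of the group. The two aryl groups are not separated either (a number 4.6 percentage points higher from compound 1 to compound 3 (within the scatter)), which places compounds 1, 2 and 3 all within the scatter of one another at the one concentration tested, and no measurement on hand offers an explanation for this.

Still open, as far as these compounds go, is whether any group at this position moves the number beyond the scatter, for example a benzyl group, a pyridine ring or a short chain such as ethyl. Also open, from the compounds shown here alone, is whether these three compounds would stay together at other concentrations, as a single-concentration read-out is not a potency.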